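The source may report more compounds than this note shows. Statements on the series, on what has been measured and on what is new or still open speak of the compounds shown alone.

Measured so far:
compound 1, `CCOC(=O)[C@H](CCC(=O)O)NC(=O)c1ccc(Sc2nc3cc(N)cc(N)c3nc2-c2ccccc2)cc1`: 33900 nM
compound 2, `COc1ccc(Sc2nc3cc(N)cc(N)c3nc2-c2ccccc2)cc1`: < 100000 nM

In a functional assay on SK-MEL-28 cells (Homo sapiens) for inhibition, read by sulforhodamine B assay, with a stated time of 48 h (on this read-out lower numbers stand for stronger inhibition of growth and higher numbers for weaker inhibition of growth), compound 1 gives 33900 nM. For compound 2 the assay reports only a limit, < 100000 nM, as recorded in the limit of < 100000 nM in this assay, at which 1 of the 2 values shown sits, so where compound 2 truly stands among these numbers is open. Compound 3, `Nc1cc(N)c2nc(-c3ccccc3)c(Sc3ccc(F)cc3)nc2c1`, differs from compound 2 by fluoro in place of methoxy on an aromatic carbon. Going by the values given here, no measured pair shares a single change, so nothing here sets the size of this step; for compound 3 the step that the limit leaves unreadable from compound 2 to compound 3 is expected to be small, without a favored direction. Compound 3 is estimated at 40000 nM, between 10000 nM and 150000 nM.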

Compound 3, concentration for total growth inhibition: 53700 nM
Beside the measured number, compound 3's estimate is 1.3-fold (0.13 log units) below it, and the stated range covers the measured number.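

Going by these compounds alone, compound 2 stands only as a limit, < 100000 nM, and no step from compound 2 to compound 3 can be read. Going by these compounds, what fluoro in place of methoxy on an aromatic carbon does to growth inhibition stays open.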